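Swapping the dithiocarbamate amine on a chloro-substituted chromone

The source may report more compounds than this note shows. Statements on the series, on what has been measured and on what is new or still open speak of the compounds shown alone.

Of the compounds shown here, three sharing a chromone-dithiocarbamate core have been measured in a functional assay on MCF7 cells (Homo sapiens) for antiproliferative activity, read by MTT assay, with a stated time of 72 h; on this read-out higher numbers stand for weaker inhibition and lower numbers for stronger inhibition. Compound 1 `O=c1cc(CSC(=S)N2CCCC2)oc2ccccc12` gives 35800 nM. Compound 2 `O=c1c(CSC(=S)N2CCOCC2)coc2cc(Cl)ccc12` gives 8100 nM, and compound 3 `O=c1c(CSC(=S)N2CCOCC2)coc2ccccc12` gives 4000 nM. Compound 2 thus holds the second highest number of the three: the step of a 2.0-fold lower number from compound 2 to compound 3 (0.31 log units; beyond the scatter) is modest but beyond the scatter, while the number of compound 1 lies further away on the higher side.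

The next compound, compound 4 `O=c1c(CSC(=S)N2CCCC2)coc2cc(Cl)ccc12`, differs from compound 2 in one place: pyrrolidin-1-yl in place of morpholin-4-yl on a thiocarbonyl carbon. Among the measured compounds shown here, no measured step follows this exact change. For the measured compounds named here, the only measured step, from compound 2 to compound 3, concerns the chloro group and not the amine, so it does not bear on it. Going by the values given here, the sole compound carrying pyrrolidin-1-yl, compound 1, also differs in how the side chain is attached to the core and in lacking the chloro group, so its high number is at best a weak hint.

On that basis compound 4 is expected to stay close to compound 2, with a step of a 1.4-fold higher number from compound 2 to compound 4 (0.13 log units; within the scatter) that may not exceed the scatter. The estimate for compound 4 in this assay is 11000 nM, with a range from 4000 nM to 35000 nM.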

Compound 4, half-maximal inhibitory concentration: 600 nM
Beside the measured number, compound 4's estimate is 18-fold (1.26 log units) above it; measured number below the stated range.
By their numbers in this assay, from the lowest: compound 4; then compound 3; then compound 2; then compound 1.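

In this assay, among the compounds shown here, the amine on the thiocarbonyl carbon proves to be a sensitive place on this chloro-substituted scaffold: pyrrolidin-1-yl in place of morpholin-4-yl gives a 14-fold lower number from compound 2 to compound 4 (1.13 log units; beyond the scatter), a large step, whereas the only step available earlier, a 2.0-fold lower number from compound 2 to compound 3 (0.31 log units; beyond the scatter), was modest and concerned the chloro group. The exchange alters two things at once, since a six-membered ring with 2 hetero atoms leaves and a five-membered ring with 1 hetero atom enters, so this single step cannot assign the difference to ring size or to the loss of the oxygen. Nothing in the available data accounts for the size of the step.

On these data alone, it remains open whether pyrrolidin-1-yl would give a step of similar size on the core of compound 3, which carries hydrogen in place of chloro. Piperidin-1-yl, a six-membered ring without the oxygen, could separate ring size from the oxygen, and an open-chain diethylamino group could show whether a ring is needed at this place at all.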